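Chloro to 4-methylpiperazin-1-yl on compound 2

The compounds below may be only part of what the source reports. "The series", "measured", "known", "first", "only" and "open" are said of these compounds alone.

In a functional assay on SW480 cells (Homo sapiens) for antiproliferative activity, read by MTT assay, with a stated time of 48 h (on this read-out higher numbers stand for weaker inhibition and lower numbers for stronger inhibition), compound 1 (`CC(=O)OC/C1=C/C[C@](C)(CCC=C(C)C)/C=C/[C@@H](OC(=O)C=C(C)C)[C@](C)(OC(C)=O)/C=C/C1=O`) gives 3520 nM and compound 2 (`CC(C)=CCC[C@]1(C)/C=C/[C@@H](OC(=O)C=C(C)C)[C@](C)(O)/C=C/C(=O)/C(CCl)=C\C1`) gives 390 nM as the lower of the two numbers, a gap beyond the scatter. Compound 3 (`CC(C)=CCC[C@]1(C)/C=C/[C@@H](OC(=O)C=C(C)C)[C@](C)(O)/C=C/C(=O)/C(CN2CCN(C)CC2)=C\C1`) carries 4-methylpiperazin-1-yl in place of chloro on a saturated chain carbon bound to a double-bonded ring carbon. Going by the values given here, no measured pair shows this change, so the expectation is loosely held. The estimated step of a 2.3-fold higher number from compound 2 to compound 3 (0.36 log units; beyond the scatter) is moderate and runs towards weaker inhibition in this assay on this read-out. Compound 3 is estimated at 900 nM with 250 nM to 3500 nM as the expected range.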

Compound 3, half-maximal inhibitory concentration: 800 nM
The estimate for compound 3 lay 1.1-fold (0.05 log units) above the measured number; the range from low to high includes it.
By their numbers in this assay, from the lowest: compound 2; then compound 3; then compound 1.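

In this assay, 4-methylpiperazin-1-yl in place of chloro on a saturated chain carbon bound to a double-bonded ring carbon gives a 2.1-fold higher number from compound 2 to compound 3 (0.31 log units; beyond the scatter). This place therefore accepts a six-membered non-aromatic ring with a modest loss of inhibition, so chloro is not a strict requirement for activity here. No measurement bearing on the cause of this step is available.

A single pair leaves open whether the step follows from the ring or from its second nitrogen. Morpholin-4-yl or dimethylamino at this place would help separate the two.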